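A few compounds are considered here, and "the series" means these few. Any claim that something is new, unique, unknown or untested is made for them only; others in the source may bear on it.

Three compounds share one core and differ only in the group carried on the oxygen attached to the aromatic ring. In an assay for inhibition of serine/threonine-protein kinase Sgk1 (Homo sapiens), with stated times of 30 min and 60 min, in the presence of a further agent that is not named here (a higher number here means a weaker inhibitor, a lower number a stronger inhibitor), compound 1 `Cc1n[nH]c2nc(-c3ccc(NS(=O)(=O)c4cc(Cl)ccc4F)cc3)nc(OCC3(CN)COC3)c12` gives 1 nM, compound 2 `Cc1n[nH]c2nc(-c3ccc(NS(=O)(=O)c4cc(Cl)ccc4F)cc3)nc(OCC(CO)CO)c12` gives 1 nM, and compound 3 `Cc1n[nH]c2nc(-c3ccc(NS(=O)(=O)c4cc(Cl)ccc4F)cc3)nc(OCCCO)c12` gives 2 nM. Compound 3 stands alongside the other two: the steps of a 2.0-fold higher number from compound 1 to compound 3 (0.30 log units; within the scatter) and a 2.0-fold higher number from compound 2 to compound 3 (0.30 log units; within the scatter) lie within the scatter, as does no change at the digits printed from compound 1 to compound 2 (within the scatter). Compound 4 `Cc1n[nH]c2nc(-c3ccc(NS(=O)(=O)c4cc(Cl)ccc4F)cc3)nc(OC3CC(C)(C)NC(C)(C)C3)c12` makes a different kind of change, (2,2,6,6-tetramethylpiperidin-4-yl in place of 3-hydroxypropyl on an oxygen on an aromatic ring). For the measured compounds named here, no measured step swaps the chain for a ring, so the three steps bear on it only by showing that the group on that oxygen has so far moved the number little. The estimate for compound 4 is 3 nM, from 0.8 nM to 12 nM. The expected step is therefore a 1.5-fold higher number from compound 3 to compound 4 (0.18 log units; within the scatter), a change still inside the usual scatter.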

Compound 4, half-maximal inhibitory concentration: 3 nM
Compound 4: the middle estimate sits on the measured number at the digits printed, and the stated range covers the measured number.
By their numbers in this assay, from the lowest: compounds 1, 2, 3 and 4 (each within the scatter of the next, the first and the last beyond it).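

Replacing the open chain on this oxygen with a ring leaves the number close: in this assay, a 1.5-fold higher number from compound 3 to compound 4 (0.18 log units; within the scatter), even though 2,2,6,6-tetramethylpiperidin-4-yl has 10 heavy atoms against 4 for 3-hydroxypropyl. For the compounds shown here, the same ring also gives the first steps beyond the scatter at this position, a 3.0-fold higher number from compound 2 to compound 4 (0.48 log units; beyond the scatter) and a 3.0-fold higher number from compound 1 to compound 4 (0.48 log units; beyond the scatter), though both are modest. No measurement shown gives a reason for these steps.

Still open, from the compounds shown here alone, is how a plain piperidin-4-yl without the four methyl groups, or a cyclohexyl ring without the nitrogen, would compare with compound 4.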